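Bromo on the fused ring of a urea series

This account rests on a few compounds, and the source may have more. Where it says the series, first, only, none or still open, it means among the compounds named here.

Compound 1 `Cc1ccc(NC(=O)Nc2nc(-c3cc4ccccc4o3)cs2)cc1` gives 500 nM in a physicochemical assay, with a stated time of 6 min; a higher number here means a weaker inhibitor, a lower number a stronger inhibitor. Compound 2 `O=C(Nc1ccc(F)cc1)Nc1nc(-c2cc3ccccc3o2)cs1` gives 1130 nM, the highest of the two numbers; the step of a 2.3-fold higher number from compound 1 to compound 2 (0.35 log units; beyond the scatter) lies beyond the scatter. Compound 3 `O=C(Nc1ccc(F)cc1)Nc1nc(-c2cc3cc(Br)ccc3o2)cs1` differs from compound 2 as follows: bromo in place of hydrogen on an aromatic carbon. Among the compounds with values here, no measured step touches this change; the single step known, a 2.3-fold higher number from compound 1 to compound 2 (0.35 log units; beyond the scatter), sits elsewhere in the structure and offers no guide. Nothing supports a step beyond the scatter, so the expected step is a 1.0-fold lower number from compound 2 to compound 3 (0.01 log units; within the scatter). Compound 3 is estimated at 1100 nM, with a range of 400 nM to 3000 nM.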

Compound 3, half-maximal inhibitory concentration: > 200000 nM
Compound 3: only a limit was reported; the forecaster's own chance of this, stated with the estimate: 3%; middle value at least 180-fold (2.25 log units) away from the limit.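

In this assay, the fused system of two rings proves sensitive to substitution: bromo in place of hydrogen on an aromatic carbon of its six-membered ring gives an at least 170-fold higher number from compound 2 to compound 3 (2.24 log units; beyond the scatter). Within the data shown here, the only earlier step, a 2.3-fold higher number from compound 1 to compound 2 (0.35 log units; beyond the scatter), concerned a different place and gave no sign of a change this large. Compound 3 stands at a limit of the assay, not at a number: the limit of > 200000 nM in this assay, at which 1 of the 3 values shown sits.

As far as these compounds go, whether this weakening is specific to bromo or extends to other groups on this carbon remains open. A methoxy or an amine here would help separate those readings.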